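This account rests on a few compounds, and the source may have more. Where it says the series, first, only, none or still open, it means among the compounds named here.

In a functional assay on PC-3 cells (Homo sapiens) for inhibition, read by sulforhodamine B assay (on this read-out lower numbers stand for stronger inhibition of growth and higher numbers for weaker inhibition of growth), compound 1 `c1ccc(-c2ccc(-c3ccc(-c4nc5ccccc5[nH]4)cc3)cc2)cc1` gives 41200 nM, compound 2 `Cc1ccc2[nH]c(-c3ccc(-c4ccc(-c5ccc(N(C)C)cc5)cc4)cc3)nc2c1` gives 8120 nM and compound 3 `CN(C)c1ccc(-c2ccc(-c3ccc(-c4nc5c(O)cccc5[nH]4)cc3)cc2)cc1` gives 8420 nM. Compound 2 thus stands level with compound 3, and both lie well under compound 1. Going to compound 4 `Cc1ccc2[nH]c(-c3ccc(-c4ccc(-c5ccccc5)cc4)cc3)nc2c1` brings (hydrogen in place of dimethylamino on an aromatic carbon), that is, hydrogen in place of dimethylamino on an aromatic carbon. Among the measured compounds shown here, the one measured step, a 1.0-fold higher number from compound 2 to compound 3 (0.02 log units; within the scatter), changes a different place and stays within the scatter, so it offers little guidance. Compound 1 also lacks dimethylamino, though it lacks the methyl too, and it gives 41200 nM. A step of a 3.7-fold higher number from compound 2 to compound 4 (0.57 log units; beyond the scatter) is therefore expected, toward weaker inhibition of growth. Compound 4 is estimated at 30000 nM, within an expected range of 12000 nM to 75000 nM.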

Compound 4, concentration for 50% growth inhibition: 100000 nM
Compound 4: the middle estimate sits 3.3-fold (0.52 log units) below what was measured, and the stated range ends below it.
By their numbers in this assay, from the lowest: compounds 2 and 3 (each within the scatter of the next); then compound 1; then compound 4.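

In this assay, the dimethylamino group on this aromatic carbon, para to a large group, proves to matter far more than compound 3 could show, since removing it gives a large loss of growth inhibition (a 12-fold higher number from compound 2 to compound 4 (1.09 log units; beyond the scatter)). The methyl does not make up for that loss, and its presence on the core goes with a modest further weakening (a 2.4-fold higher number from compound 1 to compound 4 (0.39 log units; beyond the scatter)). Nothing given here explains either step. On these data alone, whether an amino or methoxy group at this place would keep the inhibition remains open. So does whether the methyl would act the same way with dimethylamino present.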